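A few compounds are considered here, and "the series" means these few. Any claim that something is new, unique, unknown or untested is made for them only; others in the source may bear on it.

Compound 1 `CCCCCCCCCCCCCC(=O)OC(COP(=O)(O)OP(=O)(O)OC[C@H]1OC(n2ccc(N)nc2=O)[C@@H](O)[C@@H]1O)CSCCCCCCCCCCCC` and compound 2 `CCCCCCCCCCCCCCSCC(COP(=O)(O)OP(=O)(O)OC[C@H]1OC(n2ccc(N)nc2=O)[C@@H](O)[C@@H]1O)OC(=O)CCCCCCCCCCCCC` differ in a single place: ethyl in place of hydrogen on a saturated chain carbon, ten or more bonds along the chain from a sulfur. In an ADME assay for solubility (on this read-out lower numbers stand for lower solubility and higher numbers for higher solubility), compound 1 reaches only a limit of the assay, > 68000000 nM. Compound 2 likewise reaches only a limit in this assay, > 60000000 nM. The two limits leave the step that the two limits leave unreadable from compound 1 to compound 2 without a readable size. Compound 3 `CCCCCCCCCCCCCCCCSCC(COP(=O)(O)OP(=O)(O)OC[C@H]1OC(n2ccc(N)nc2=O)[C@@H](O)[C@@H]1O)OC(=O)CCCCCCCCCCC` has a core that differs from that of compound 1 in a way that is not broken down here. In this assay compound 3 also reaches only a limit, > 64000000 nM. Among the compounds with values here, compound 4 `CCCCCCCCCCCCCCCCCCSCC(COP(=O)(O)OP(=O)(O)OC[C@H]1OC(n2ccc(N)nc2=O)[C@@H](O)[C@@H]1O)OC(=O)CCCCCCCCCCC` is not yet measured; it differs from compound 3 by ethyl in place of hydrogen on a saturated chain carbon, ten or more bonds along the chain from a sulfur, the same change as the one from compound 1 to compound 2. All three measured compounds sit at a limit in this assay, as the limit of > 60000000 nM in this assay, at which 1 of the 3 values shown sits, the limit of > 64000000 nM in this assay, at which 1 of the 3 values shown sits, and the limit of > 68000000 nM in this assay, at which 1 of the 3 values shown sits, show, so the expectation is that compound 4 will again sit at a limit, and the expected step that the limit leaves unreadable from compound 3 to compound 4 is taken as small. In this assay the estimated value for compound 4 is 70000000 nM, with a range from 30000000 nM to 160000000 nM.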

Compound 4, solubility: > 54000000 nM
Compound 4: a limit, no number (the forecaster's own chance of this, stated with the estimate: 85%); the middle value lies beyond the limit too.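

In this assay compound 4 reaches only a limit, > 54000000 nM, not a number. Compound 3 also sits at a limit, so the step from compound 3 to compound 4 cannot be read. The compounds shown leave open the actual solubility of each compound and whether placing ethyl in place of hydrogen changes it at all.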